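The source may hold more compounds than are shown below. What is called first, only, known or untested is meant among the compounds shown, and "the series" means these compounds.

Compound 1 `CC(C)NC(=O)[C@H]1CC[C@@H](n2/c(=N/C(=O)c3ccc(F)cc3)[nH]c3ccc(CN4CC(C(C)(C)O)C4)cc32)CC1` is measured in an in vitro ADME assay on microsomes from liver (Rattus norvegicus) for metabolic stability; a lower number here means slower removal, a higher number faster removal of the compound. Compound 1 gives < 14 mL.min-1.g-1, which is a limit of the assay rather than a number. Compound 2 `CC(C)NC(=O)[C@H]1CC[C@@H](n2/c(=N/C(=O)c3cccnc3)[nH]c3ccc(CN4CCC(C(C)(C)O)CC4)cc32)CC1` gives < 14 mL.min-1.g-1 in this assay, again a limit. Both results sit at the limit of < 14 mL.min-1.g-1 in this assay, at which 2 of the 2 values shown sit, so the shown numbers carry no spread at all. Compound 3 `CC(C)NC(=O)[C@H]1CC[C@@H](n2/c(=N/C(=O)c3ccc(F)cc3)[nH]c3ccc(CNCC(C)(C)O)cc32)CC1` carries (2-hydroxy-2-methylpropyl)amino in place of 3-(1-hydroxy-1-methylethyl)azetidin-1-yl on a saturated chain carbon bound to an aromatic carbon. For the measured compounds named here, no step between measured compounds exists here, and the change from compound 1 is expected to give a step of a number no lower from compound 1 to compound 3 (the limit leaves the size open) in this assay, none beyond the scatter. Compound 3 is therefore estimated at 14 mL.min-1.g-1, within a range from 6 mL.min-1.g-1 to 35 mL.min-1.g-1.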

Compound 3, intrinsic clearance in microsomes: 68 mL.min-1.g-1
Compound 3: middle estimate off by 4.9-fold (0.69 log units), on the low side, outside the stated range (above it).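

In this assay, replacing 3-(1-hydroxy-1-methylethyl)azetidin-1-yl with the ring-free (2-hydroxy-2-methylpropyl)amino on this saturated chain carbon gives an at least 4.8-fold higher number from compound 1 to compound 3 (0.68 log units; beyond the scatter). For the compounds shown here, this position is therefore not indifferent to the group it carries, which the earlier compounds could not show. The result for compound 1 is a limit, so the true step may be larger: the limit of < 14 mL.min-1.g-1 in this assay, at which 2 of the 3 values shown sit.

From the compounds shown here alone, whether the loss of the ring or the added hydrogen-bond donor matters more stays open. A morpholin-4-yl group or a methyl on the chain nitrogen at this place could help separate the two.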